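Swapping fluoro for bromo on a benzofuran amidoxime inhibitor

A few compounds are considered here, and "the series" means these few. Any claim that something is new, unique, unknown or untested is made for them only; others in the source may bear on it.

Measured so far:
compound 1, `COCc1cc2cc(/C(=N\O)Nc3cccc(Br)c3)ccc2o1`, 930 nM
compound 2, `O/N=C(/Nc1cccc(F)c1)c1ccc2oc(COCC3CC3)cc2c1`, 2200 nM

Both compounds were tested in an assay on isolated protein for inhibition of Indoleamine 2,3-dioxygenase 1 (Homo sapiens), read by spectrophotometry; on this read-out lower numbers stand for stronger inhibition and higher numbers for weaker inhibition. Compound 2 stands at the higher of the two numbers, and its gap to compound 1 lies beyond the usual scatter, so compound 2 is the weaker inhibitor of the pair. The two compounds differ in more than one place, so no single step can be read between them.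

Compound 3, `O/N=C(/Nc1cccc(Br)c1)c1ccc2oc(COCC3CC3)cc2c1`, has not yet been measured. It keeps the whole of compound 2 except for one change: bromo in place of fluoro on an aromatic carbon. Compound 1 carries the same bromo group and is the stronger of the two measured compounds, so this assay is expected to move in the direction of stronger inhibition, by a modest step. The expected step in this assay is a 2.0-fold lower number from compound 2 to compound 3 (0.30 log units; within the scatter). Compound 3 is estimated at 1100 nM, with a likely range from 400 nM to 3000 nM.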

Compound 3, half-maximal inhibitory concentration: 400 nM
Beside the measured number, compound 3's estimate is 2.8-fold (0.44 log units) above it, and the stated range covers the measured number.
By their numbers in this assay, from the lowest: compound 3; then compound 1; then compound 2.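

In this assay, bromo in place of fluoro gives a 5.5-fold lower number from compound 2 to compound 3 (0.74 log units; beyond the scatter) with all else held the same, so this place on the ring responds to the choice of halogen, which the earlier pair, differing in more than one place, could not show. With bromo held constant, cyclopropyl in place of hydrogen on the side chain gives a 2.3-fold lower number from compound 1 to compound 3 (0.37 log units; beyond the scatter), so the side chain also affects the read-out. Nothing measured here accounts for either step.

The compounds shown cover only fluoro and bromo at this place, so the effect of chloro, methoxy or an amine there remains open. Also open, on these data alone, is whether the halogen swap would give a similar step on the side chain of compound 1, or whether a longer chain would extend the cyclopropyl gain.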